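The source may hold more compounds than are shown below. What is called first, only, known or untested is meant among the compounds shown, and "the series" means these compounds.

Compound 2 `CCOc1ccccc1-n1nncc1CN1C(=O)C2(C(C#N)=C(N)Oc3c(N)cc4nc5ccccc5nc4c32)c2ccccc21` and compound 1 `N#CC1=C(N)Oc2c(N)cc3nc4ccccc4nc3c2C12C(=O)N(Cc1cnnn1-c1ccc(F)cc1)c1ccccc12` share the same core and differ only in the group carried on an aromatic nitrogen. In an ADME assay on L02 cells (Homo sapiens) for antiproliferative activity, read by MTT assay, with a stated time of 48 h (on this read-out higher numbers stand for weaker inhibition and lower numbers for stronger inhibition), compound 1 gives > 50000 nM, which is a limit of the assay rather than a measured number. In this assay compound 2 likewise gives > 50000 nM, again a limit. The step that the two limits leave unreadable from compound 1 to compound 2 therefore cannot be read, since (the limit of > 50000 nM in this assay, at which 2 of the 2 values shown sit). Compound 2 thus stands at the limit, with no number of its own on this read-out.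

Compound 3 `N#CC1=C(N)Oc2c(N)cc3nc4ccccc4nc3c2C12C(=O)N(Cc1cnnn1-c1ccc([N+](=O)[O-])cc1[N+](=O)[O-])c1ccccc12` has not yet been measured. It differs from compound 2 in this way: 2,4-dinitrophenyl in place of 2-ethoxyphenyl on an aromatic nitrogen. For the measured compounds named here, only one measured step exists, and although it touches the same position, its size is unreadable, so no step speaks for or against a change here. Compound 3 is therefore expected to stay at or near the limit because of the limit of > 50000 nM in this assay, at which 2 of the 2 values shown sit, with an estimated step that the limit leaves unreadable from compound 2 to compound 3. The estimate for compound 3 in this assay is 60000 nM, within a range from 20000 nM to 200000 nM.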

Compound 3, half-maximal inhibitory concentration: 22800 nM
For compound 3 the middle estimate is 2.6-fold (0.42 log units) above the measured one; measured number inside the range.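

In this assay, the group on the aromatic nitrogen of the five-membered ring can shift the read-out, which the first two compounds could not show, since both sit at a limit. Putting 2,4-dinitrophenyl in place of 2-ethoxyphenyl gives an at least 2.1-fold lower number from compound 2 to compound 3 (0.34 log units; beyond the scatter) and putting it in place of 4-fluorophenyl gives an at least 2.1-fold lower number from compound 1 to compound 3 (0.34 log units; beyond the scatter), so on this read-out, where a lower number means stronger inhibition, compound 3 inhibits these cells more strongly than either of the other two. Both steps give only a minimum size, and the step between compound 1 and compound 2 cannot be read: the limit of > 50000 nM in this assay, at which 2 of the 3 values shown sit.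

For the compounds shown here, with only three compounds, it remains open whether the change depends on having both nitro groups of 2,4-dinitrophenyl or whether a single nitro group on the phenyl ring would do the same. As far as these compounds go, it also remains open whether a quite different group on the phenyl ring, such as an amine or a carboxylic acid, would bring the number down further, leave it where it is, or return it to the limit.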